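The compounds below may be only part of what the source reports. "The series", "measured", "known", "first", "only" and "open" are said of these compounds alone.

In an ADME assay on microsomes from liver (Homo sapiens) for metabolic stability, read by LC-MS, with a stated time of 30 min, tested at 1 uM (a lower number here means that less of the compound is left, a higher number that more of the compound is left), compound 3 (`O=C(NCc1ccc(S(=O)(=O)c2cc(F)cc(F)c2)cc1)c1cc2cnccc2[nH]1`) gives 82% and lies within the scatter of compound 1 (`O=C(NCc1ccc(S(=O)(=O)c2cccc(F)c2)cc1)c1cc2cnccc2[nH]1`) at 79% while compound 2 (`O=C(NCc1ccc(S(=O)(=O)c2ccccc2C(F)(F)F)cc1)c1cc2cnccc2[nH]1`) gives 52% and stands clearly lower. Compound 4 (`O=C(NCc1ccc(S(=O)(=O)c2cc(F)cc(F)c2)cc1)c1cc2ccncc2o1`) carries a group of 9 heavy atoms (7 carbon, 1 nitrogen, 1 oxygen; one five-membered aromatic ring with 1 hetero atom, one six-membered aromatic ring with 1 hetero atom) in place of a group of 9 heavy atoms (7 carbon, 2 nitrogen; one five-membered aromatic ring with 1 hetero atom, one six-membered aromatic ring with 1 hetero atom), on a carbonyl carbon and keeps the 3,5-difluorophenyl on the sulfonyl sulfur. All measured steps concern the group on that sulfur: a number 27 percentage points lower from compound 1 to compound 2 (beyond the scatter) and a number 30 percentage points higher from compound 2 to compound 3 (beyond the scatter) are modest, and a number 3 percentage points higher from compound 1 to compound 3 (within the scatter) stays within the scatter. None touches the group on the carbonyl carbon, so the data offer only a loose guide to size. The estimated step, slightly downward, is a number 6 percentage points lower from compound 3 to compound 4 (within the scatter) and no change beyond the scatter is expected. The expected value for compound 4 is 76% (estimated range 56% to 90%).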

Compound 4, percent of the compound remaining: 77%
The estimate for compound 4 lay 1 percentage points below the measured number; the measured number falls inside the stated range.
By their numbers in this assay, from the lowest: compound 2; then compounds 4, 1 and 3 (each within the scatter of the next).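

Within the data shown here, this is the first step at the carbonyl carbon, where earlier steps concerned only the group on the sulfonyl sulfur. In this assay, a number 5 percentage points lower from compound 3 to compound 4 (within the scatter), so a group with 1 hydrogen-bond donor and 1 hydrogen-bond acceptor gives way to one with 0 hydrogen-bond donors and 2 hydrogen-bond acceptors without a change beyond the scatter. No supporting measurement bears on this result.

As far as these compounds go, whether the exchange holds alongside the 2-(trifluoromethyl)phenyl of compound 2 remains open. So does the outcome for a group on the carbonyl carbon carrying an amine or a carboxylic acid.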